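Ester variation on a triterpenoid diol series: nitrophenyl to furanyl

The compounds below may be only part of what the source reports. "The series", "measured", "known", "first", "only" and "open" are said of these compounds alone.

Measured compounds:
compound 1, `CC1=CCC2C(CC[C@@]2(C)O)C(C)(C)C1CC[C@@H]1[C@@]2(C)CC[C@@H](O)C(C)(C)O[C@@H]2CC[C@]1(C)O`, 44500 nM
compound 2, `CC(=O)O[C@H]1CC[C@]2(C)[C@H](CC[C@@](C)(O)[C@H]2CC[C@@H]2C(C)=CC[C@H]3[C@H](CC[C@]3(C)OC(C)=O)C2(C)C)OC1(C)C`, 39200 nM
compound 3, `CC1=CC[C@H]2[C@H](CC[C@]2(C)O)C(C)(C)[C@@H]1CC[C@H]1[C@]2(C)CC[C@H](OC(=O)c3ccc([N+](=O)[O-])cc3)C(C)(C)O[C@H]2CC[C@@]1(C)O`, 21600 nM

All three were run in a functional assay on MCF7 cells (Homo sapiens) for antiproliferative activity, read by MTT assay, with a stated time of 72 h; on this read-out lower numbers stand for stronger inhibition and higher numbers for weaker inhibition. Compound 3 has the lowest of the three numbers, but its gap to compound 2 is within the scatter, so no order between those two is claimed; only compound 1 stands beyond the scatter from compound 3. Within the data shown here, no pair of measured compounds differs in a single place, so no measured step is available to lean on.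

Compound 4, `CC1=CC[C@H]2[C@H](CC[C@]2(C)O)C(C)(C)[C@@H]1CC[C@H]1[C@]2(C)CC[C@H](OC(=O)c3ccco3)C(C)(C)O[C@H]2CC[C@@]1(C)O`, has not yet been measured in this assay. It differs from compound 3 in one place: furan-2-yl in place of 4-nitrophenyl on a carbonyl carbon. Both compounds carry an ester at the same oxygen; the change exchanges one aromatic acyl group for a smaller one.

With no measured step of this kind in the series, the expectation is a small step, if any, from compound 3 to compound 4, and one that may fall within the scatter, so a 1.3-fold higher number from compound 3 to compound 4 (0.11 log units; within the scatter) is estimated. Compound 4 is therefore expected to give about 28000 nM in this assay, with a range from 12000 nM to 65000 nM.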

Compound 4, half-maximal inhibitory concentration: 25700 nM
Compound 4: middle estimate off by 1.1-fold (0.04 log units), on the high side; low and high end bracket the measured number.
By their numbers in this assay, from the lowest: compounds 3, 4, 2 and 1 (each within the scatter of the next, the first and the last beyond it).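

In this assay, the series now has its first single-place step at this ester oxygen: a 1.2-fold higher number from compound 3 to compound 4 (0.08 log units; within the scatter), within the scatter, so no order is claimed between the two esters. For this one pair, the exchange of 4-nitrophenyl, with 9 heavy atoms, for furan-2-yl, with 5 heavy atoms, gives no measurable difference, and an aromatic acyl group with no nitrogen reads alike within the scatter. No measured data bear on why these two acyl groups read alike.

From the compounds shown here alone, what an acyl group carrying an amine, a carboxylic acid or a longer alkyl chain would do at this oxygen remains open. The contribution of the ester itself also remains open, since no single-place step among the compounds shown isolates it.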